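A few compounds are considered here, and "the series" means these few. Any claim that something is new, unique, unknown or untested is made for them only; others in the source may bear on it.

Series notes. Compound 1 `CCOC(=O)C1=C(Nc2ccccc2)S/C(=C\c2ccc[nH]2)C1=O` gives 49.2% in a functional assay on JAR cells (Homo sapiens) for inhibition, read by MTT assay, with a stated time of 72 h, tested at 10 uM; on this read-out higher numbers stand for more inhibition at the one concentration tested (going by the name of the read-out) and lower numbers for less inhibition; compound 2 `CCOC(=O)C1=C(Nc2ccc(F)cc2)S/C(=C\c2ccc[nH]2)C1=O` gives 61.5%. Compound 2 stands highest of the two, with the step of a number 12.3 percentage points higher from compound 1 to compound 2 (beyond the scatter) beyond the scatter. Compound 3 `CCOC(=O)C1=C(Nc2ccc(C(F)(F)F)cc2)S/C(=C\c2ccc[nH]2)C1=O` is not yet measured; the change trifluoromethyl in place of fluoro on an aromatic carbon puts trifluoromethyl at the position that already carries fluoro in compound 2. Among the measured compounds shown here, only the step of a number 12.3 percentage points higher from compound 1 to compound 2 (beyond the scatter) bears on this, and it does not address trifluoromethyl, so a step within the scatter or a small rise is expected, a number 3.5 percentage points higher from compound 2 to compound 3 (within the scatter). Compound 3 is estimated at 65%, range 45% to 82%.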

Compound 3, a percentage reported as inhibition, at one concentration (the size of the read-out at that concentration, not a potency): 38.5%
Compound 3: the middle estimate sits 26.5 percentage points above what was measured; the whole stated range lies above it.
By their numbers in this assay, from the lowest: compound 3; then compound 1; then compound 2.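

At this position on the six-membered aromatic ring, para to a large group, this assay shows that the change does not act in one direction: trifluoromethyl gives a number 23 percentage points lower from compound 2 to compound 3 (beyond the scatter) and also a number 10.7 percentage points lower from compound 1 to compound 3 (beyond the scatter) in the comparison with hydrogen. The position therefore responds both ways, with the fluoro compound 2 on the upper side of the hydrogen compound 1 and the trifluoromethyl compound 3 on the lower side. Nothing available explains this reversal.

As far as these compounds go, whether chloro, a nitrile or an amine here would follow fluoro or trifluoromethyl stays open. So does whether this order holds at other places on the ring.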